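The source may report more compounds than this note shows. Statements on the series, on what has been measured and on what is new or still open speak of the compounds shown alone.

In a functional assay on a cell-free system (Platelet, plasma, Homo sapiens) for inhibition (a higher number here means a weaker inhibitor, a lower number a stronger inhibitor), three compounds that share one core and differ only in the group on the carbonyl carbon have been measured. Compound 2 `Cc1ccc(N(CCN2CCC(OCC(=O)O)CC2)C(=O)c2cccc(Cl)c2)cc1` gives 100 nM. Compound 3 `Cc1ccc(N(CCN2CCC(OCC(=O)O)CC2)C(=O)c2cccc(C(F)(F)F)c2)cc1` gives 20000 nM, the higher of the two actual numbers, which places it at the weak end of the series. Compound 1 `Cc1ccc(N(CCN2CCC(OCC(=O)O)CC2)C(=O)c2ccc(C(F)(F)F)cc2)cc1` gives > 10000 nM, which is a limit of the assay and not a number. The data therefore show a step that the limit leaves unreadable from compound 1 to compound 3.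

The next structure is compound 4 `COc1cc(OC)cc(C(=O)N(CCN2CCC(OCC(=O)O)CC2)c2ccc(C)cc2)c1`, with 3,5-dimethoxyphenyl in place of 3-(trifluoromethyl)phenyl on a carbonyl carbon. Two measured steps at this same place bear on the change: a 200-fold higher number from compound 2 to compound 3 (2.30 log units; beyond the scatter) and an at least 100-fold lower number from compound 1 to compound 2 (2.00 log units; beyond the scatter). Both are large, so a sizeable move would not be surprising here, although neither step involves a methoxy group. With compound 3 at 20000 nM, most of the measured range lies on the stronger side, so a drop is the more likely direction, though probably a smaller one than the full distance to compound 2, which gives 100 nM. The expected change is a 10-fold lower number from compound 3 to compound 4 (1.00 log units; beyond the scatter). In this assay the expected value for compound 4 is 2000 nM, within an estimated range of 200 nM to 20000 nM.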

Compound 4, half-maximal inhibitory concentration: 530 nM
Estimate against measurement, compound 4: 3.8-fold (0.58 log units) above; measured number inside the range.
By their numbers in this assay, from the lowest: compound 2; then compound 4; then compound 3.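

In this assay, the change at this place on the carbonyl carbon gives a 38-fold lower number from compound 3 to compound 4 (1.58 log units; beyond the scatter), which shows that a group other than 3-chlorophenyl can also lie far from the weak end of the series; the entering 3,5-dimethoxyphenyl counts 2 hydrogen-bond acceptors where the leaving 3-(trifluoromethyl)phenyl counts 0. It still falls short of 3-chlorophenyl, with a 5.3-fold higher number from compound 2 to compound 4 (0.72 log units; beyond the scatter), so compound 2 keeps the lowest number of the four, and among these compounds the two that carry trifluoromethyl are the two at the weak end. The remaining step, an at least 18-fold lower number from compound 1 to compound 4 (1.27 log units; beyond the scatter), rests on a limit of the assay and not on a number: the limit of > 10000 nM in this assay, at which 1 of the 4 values shown sits.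

The compounds shown leave open whether a single methoxy group, as in 3-methoxyphenyl, would match the two in 3,5-dimethoxyphenyl, and so whether both are needed for the gain over 3-(trifluoromethyl)phenyl. They also leave open how 3-bromophenyl, 3-fluorophenyl or 4-chlorophenyl would stand against 3-chlorophenyl, and whether an amine on this ring would be tolerated at all.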